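The source may hold more compounds than are shown below. What is called first, only, known or untested is meant among the compounds shown, and "the series" means these compounds.

Compound 2, whose structure is `Nc1scc(CN2CCN(c3cc(F)cc(F)c3)CC2)c1C(=O)c1ccc(Cl)cc1`, sits at the low end of the two numbers recorded in a functional assay on CHO cells with adenosine receptor A1 (Homo sapiens) as the target, read by cAMP accumulation and immunoassay, with a stated time of 6 min, tested at 1 uM (a lower number here means a stronger effect, a higher number a weaker effect of the compound at the concentration tested), where compound 2 gives -66%. Within the data shown here, the only neighbour is compound 1, with structure `Nc1scc(CN2CCN(c3cccnc3)CC2)c1C(=O)c1ccc(Cl)cc1`; in this assay compound 1 gives -2.7%. Among the measured compounds shown here, the one measured step, a number 63.3 percentage points lower from compound 1 to compound 2 (beyond the scatter), accompanied the exchange of pyridin-3-yl for 3,5-difluorophenyl on an amine nitrogen in a ring.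

Compound 3, with structure `Nc1scc(CN2CCN(c3c(F)cccc3F)CC2)c1C(=O)c1ccc(Cl)cc1`, has not been measured in this assay. It differs from compound 2 in this way: 2,6-difluorophenyl in place of 3,5-difluorophenyl on an amine nitrogen in a ring. The step from compound 1 to compound 2 exchanged one kind of aromatic group for another, whereas the step to compound 3 keeps the difluorophenyl group and only redistributes the two fluorine atoms on it. For the measured compounds named here, no measured step of that kind is available, so the large step from compound 1 to compound 2 gives no direct guide to its size. Compound 3 is therefore expected to retain a clear effect, though a step of a number 26 percentage points higher from compound 2 to compound 3 (beyond the scatter) toward a weaker read-out is estimated as the more likely outcome. For compound 3 the estimated value is -40%, within a range from -80% to 0%.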

Compound 3, a percentage reported as activity, at one concentration (the size of the read-out at that concentration, not a potency): -65%
For compound 3 the middle estimate is 25 percentage points above the measured one; low and high end bracket the measured number.
By their numbers in this assay, from the lowest: compounds 2 and 3 (each within the scatter of the next); then compound 1.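

In this assay, replacing 3,5-difluorophenyl with 2,6-difluorophenyl gave a number 1 percentage points higher from compound 2 to compound 3 (within the scatter), so these two fluorine arrangements on the ring attached to the amine nitrogen could not be told apart. The exchange of pyridin-3-yl for 2,6-difluorophenyl gave a number 62.3 percentage points lower from compound 1 to compound 3 (beyond the scatter), a large step like a number 63.3 percentage points lower from compound 1 to compound 2 (beyond the scatter), which shows that the large difference from the pyridin-3-yl compound is not confined to a single difluorophenyl pattern. No supporting evidence is available to explain why the two fluorine arrangements read alike or why both differ so strongly from pyridin-3-yl.

The compounds shown leave open whether the fluorine atoms contribute at all, since an unsubstituted phenyl group at this position would be needed to separate their part from that of replacing the pyridine ring with an all-carbon aromatic ring. They also leave open whether other arrangements, such as 2,4-difluorophenyl or a single-fluorine 3-fluorophenyl group, or other substituents, such as chlorine or methoxy, would fit the same picture.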